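The source may hold more compounds than are shown below. What is called first, only, known or untested is meant among the compounds shown, and "the series" means these compounds.

Compound 1, `COc1ccccc1C(=O)Nc1cccc(NC(=O)c2cccc(F)c2)c1`, gives 6480 nM in an in vitro functional assay on HEK293-A cells for antagonist activity at metabotropic glutamate receptor 5 (Rattus norvegicus), read by calcium flux; a higher number here means a weaker inhibitor, a lower number a stronger inhibitor.
Compound 2, `COc1ccccc1C(=O)Nc1cccc(NC(=O)c2ccc(F)cc2)c1`, gives > 30000 nM in this assay; this is a limit of the assay and not a number.

Compound 2 therefore stands at the limit of > 30000 nM in this assay, at which 1 of the 2 values shown sits, the weaker end of what has been seen here. Among the compounds with values here, the only measured step, an at least 4.6-fold higher number from compound 1 to compound 2 (0.66 log units; beyond the scatter), concerns the fluorophenyl on the other carbonyl and leaves the present change untouched. Compound 3, `O=C(Nc1cccc(NC(=O)c2cccc(Cl)c2)c1)c1ccc(F)cc1`, differs from compound 2 by 3-chlorophenyl in place of 2-methoxyphenyl on a carbonyl carbon. No measured step bears on this change, so nothing shown says in which direction it should move the number. Compound 3 is expected to stay close to where compound 2 stands, with the step of a number no higher from compound 2 to compound 3 (the limit leaves the size open) expected to lie within the scatter, and a fair chance that the assay again reports only a limit. The estimate for compound 3 is 30000 nM, in the range 8000 nM to 100000 nM.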

Compound 3, half-maximal inhibitory concentration: > 30000 nM
Compound 3 gave a limit, no number; the forecaster's own chance of this, stated with the estimate: 60%; the middle value lies on the limit itself.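

Compound 2 and compound 3 each give only a limit of the assay and not a number, so no step between them can be read: the limit of > 30000 nM in this assay, at which 2 of the 3 values shown sit.

The compounds shown leave open whether 3-chlorophenyl in place of 2-methoxyphenyl on a carbonyl carbon changes the number at all.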